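The source may hold more compounds than are shown below. What is called first, only, known or untested is meant among the compounds shown, and "the series" means these compounds.

Measured compounds in a functional assay on NCI-H1975 cells (Homo sapiens) for antiproliferative activity, read by MTT assay, with a stated time of 72 h; on this read-out lower numbers stand for stronger inhibition and higher numbers for weaker inhibition:
compound 1 `C#Cc1cccc(Nc2ncnc3ccc(NC(=S)Nc4ccc(S(N)(=O)=O)cc4)cc23)c1`: 13400 nM
compound 2 `NS(=O)(=O)c1ccc(NC(=S)Nc2ccc3ncnc(Nc4ccc(Cl)c(C(F)(F)F)c4)c3c2)cc1`: 11800 nM
compound 3 `NS(=O)(=O)c1ccc(NC(=S)Nc2ccc3ncnc(Nc4cccc(F)c4)c3c2)cc1`: 9660 nM

All three keep the shared core and the same remainder of the molecule; they differ only in the aryl group sitting on the nitrogen on the aromatic ring. Compound 3 stands at the low end of the three numbers, but the gaps to the other two are small: a 1.4-fold lower number from compound 1 to compound 3 (0.14 log units; within the scatter) and a 1.2-fold lower number from compound 2 to compound 3 (0.09 log units; within the scatter), and the remaining pair shows a 1.1-fold lower number from compound 1 to compound 2 (0.06 log units; within the scatter). None of the three compounds can be separated from the others on these data.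

Compound 4 `CCc1ccc(Nc2ncnc3ccc(NC(=S)Nc4ccc(S(N)(=O)=O)cc4)cc23)cc1` carries the same core and differs from compound 3 in one place: 4-ethylphenyl in place of 3-fluorophenyl on a nitrogen on an aromatic ring. Among the measured compounds shown here, the steps that bear on this exchange are the two earlier swaps of the aryl group at the same nitrogen, a 1.2-fold lower number from compound 2 to compound 3 (0.09 log units; within the scatter) and a 1.1-fold lower number from compound 1 to compound 2 (0.06 log units; within the scatter), both within the scatter, as is the single-substituent exchange a 1.4-fold lower number from compound 1 to compound 3 (0.14 log units; within the scatter). For the measured compounds named here, three different aryl groups at this position have given numbers that cannot be told apart, so no step beyond the scatter is expected in this assay, with the caveat that none of the measured three carries an ethyl group.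

Compound 4 is therefore expected to give about 11000 nM, with a range from 5000 nM to 25000 nM. The expected step is a 1.1-fold higher number from compound 3 to compound 4 (0.06 log units; within the scatter), essentially flat.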

Compound 4, half-maximal inhibitory concentration: 38700 nM
Compound 4: the middle estimate sits 3.5-fold (0.55 log units) below what was measured; the whole stated range lies below it.
By their numbers in this assay, from the lowest: compounds 3, 2 and 1 (each within the scatter of the next); then compound 4.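

In this assay, the aryl group on the nitrogen on an aromatic ring is not as silent as the first three compounds suggested: 4-ethylphenyl gives a 4.0-fold higher number from compound 3 to compound 4 (0.60 log units; beyond the scatter), a 3.3-fold higher number from compound 2 to compound 4 (0.52 log units; beyond the scatter) and a 2.9-fold higher number from compound 1 to compound 4 (0.46 log units; beyond the scatter), so the series shows a modest but real loss where the earlier exchanges showed none. Compound 4 is the weakest of the four on this read-out, and the change is not tied to a 4-substituent as such, since compound 2, with its 4-chloro-3-(trifluoromethyl)phenyl group, cannot be told apart from compound 1 or compound 3. Nothing available explains why the 4-ethylphenyl group stands apart from the other three aryl groups.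

With a single ethyl-bearing compound, the step cannot be assigned to the ethyl group in general or to the 4-ethylphenyl arrangement in particular. Going by these compounds, whether 3-ethylphenyl, 4-methylphenyl or 4-propylphenyl would stay with compound 4 or return to the level of the other three remains open, as does whether a longer chain would widen the step.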